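A few compounds are considered here, and "the series" means these few. Any claim that something is new, unique, unknown or untested is made for them only; others in the source may bear on it.

Measured in a functional assay on CHO cells (Homo sapiens) for antiproliferative activity against CHO (Cricetulus griseus), read by sulforhodamine B assay, with a stated time of 48 h; on this read-out higher numbers stand for weaker inhibition and lower numbers for stronger inhibition:
Compound 1 `O=C1NCCN1c1ccc(S(=O)(=O)Nc2ccc3[nH]ccc3c2)cc1`: 1310 nM
Compound 2 `Cc1cccc(NS(=O)(=O)c2ccc(N3CCNC3=O)cc2)c1`: 230 nM
Compound 3 `CCc1cccc(NS(=O)(=O)c2ccc(N3CCNC3=O)cc2)c1`: 230 nM

Compound 3, at 230 nM, stands level with compound 2, and together they hold the lowest of the three numbers, while compound 1 stands clearly higher at 1310 nM. The next compound is compound 4 `O=C1NCCN1c1ccc(S(=O)(=O)Nc2cccc(Br)c2)cc1`, in which bromo takes the place of ethyl on an aromatic carbon, meta to a large group: bromo in place of ethyl on an aromatic carbon. Among the measured compounds shown here, only one measured step bears on this change, and it is an indirect guide: no change at the digits printed from compound 2 to compound 3 (within the scatter), where methyl replaces hydrogen on a saturated chain carbon bound to an aromatic carbon. For the measured compounds named here, no measured compound carries bromo, so the data offer no direct precedent for it. With that single step as the guide, no step beyond the scatter is expected in this assay, and no direction is favoured. The expected step is a 1.1-fold higher number from compound 3 to compound 4 (0.04 log units; within the scatter). For compound 4 the estimated value is 250 nM, with an expected range from 100 nM to 650 nM.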

Compound 4, half-maximal inhibitory concentration: 250 nM
Compound 4: the middle estimate sits on the measured number at the digits printed; the range from low to high includes it.
By their numbers in this assay, from the lowest: compounds 2, 3 and 4 (each within the scatter of the next); then compound 1.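

In this assay, the earlier compounds had shown only that lengthening a saturated chain on this aromatic carbon left the number unchanged at the digits printed. Compound 4 extends that picture beyond alkyl groups: putting bromo in place of ethyl gives a 1.1-fold higher number from compound 3 to compound 4 (0.04 log units; within the scatter), and putting bromo in place of methyl gives a 1.1-fold higher number from compound 2 to compound 4 (0.04 log units; within the scatter), so a single bromine atom and a chain of two carbons stand level here. No available evidence explains this equivalence.

As far as these compounds go, whether an amine, a carboxylic acid, a methoxy group or a longer chain in this place would also stay level remains open. Also open, from the compounds shown here alone, is which feature sets compound 1 apart from the other three, as it differs from them in more than one place.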